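Working notes on compound 4 in the cytotoxicity series

The source may hold more compounds than are shown below. What is called first, only, known or untested is meant among the compounds shown, and "the series" means these compounds.

Measured so far in a toxicity assay on HeLa cells (Homo sapiens) for cytotoxicity, read by MTT assay, with a stated time of 48 h; on this read-out higher numbers stand for weaker inhibition of growth and lower numbers for stronger inhibition of growth:
Compound 1 `CCOc1ccc2nc(Cl)c(/C=C3\SC(=S)NC3=O)cc2c1` gives > 100 ug/mL, a limit of the assay.
Compound 2 `O=C1NC(=S)S/C1=C\c1cc2cc(Cl)ccc2nc1Cl` gives > 100 ug/mL, a limit of the assay.
Compound 3 `O=C1NC(=S)S/C1=C\c1cc2cc(F)ccc2nc1Cl` gives > 100 ug/mL, a limit of the assay.

Compound 3 therefore stands only at a limit in this assay, and the two further values shown are limits as well, so no order among compound 1, compound 2 and compound 3 can be read. The three measured steps, a step that the two limits leave unreadable from compound 1 to compound 2, a step that the two limits leave unreadable from compound 1 to compound 3 and a step that the two limits leave unreadable from compound 2 to compound 3, are all of unreadable size due to the limit of > 100 ug/mL in this assay, at which 3 of the 3 values shown sit.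

Compound 4 `O=C(O)CN1C(=O)/C(=C/c2cc3cc(F)ccc3nc2Cl)SC1=S` differs from compound 3 by carboxymethyl in place of hydrogen on an amide-type nitrogen in a ring. For the measured compounds named here, none of the measured steps bears on this change: each of them swaps a substituent on an aromatic carbon, and none has a readable size. Going by the values given here, the series thus gives no direction for the step in this assay; the only evidence is that every value sits at the limit. On that basis compound 4 is expected to give 150 ug/mL, with an estimated range from 40 ug/mL to 600 ug/mL, most probably again reported as a limit. The expected step is a step that the limit leaves unreadable from compound 3 to compound 4, which is not expected to be beyond the scatter.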

Compound 4, concentration for 50% growth inhibition: > 100 ug/mL
Compound 4: no number, only a limit; the forecaster's own chance of this, stated with the estimate: 75%; the middle value lies beyond the limit too.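

In this assay compound 4 gives > 100 ug/mL as a limit of the assay. No step can be read from compound 3 to compound 4, due to the limit shared across the series: the limit of > 100 ug/mL in this assay, at which 4 of the 4 values shown sit.

The compounds shown leave open whether carboxymethyl in place of hydrogen on the ring nitrogen changes growth inhibition at all, and in which direction.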